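Phenethyloxy in Place of Benzamido on the Shared Core

The compounds below may be only part of what the source reports. "The series", "measured", "known", "first", "only" and "open" are said of these compounds alone.

Of the compounds shown here, three with one shared core have been measured in a functional assay on HEK293 cells for agonist activity at G-protein coupled receptor 39 (Homo sapiens), read by scintillation proximity assay and inositol phosphate accumulation, with a stated time of 75 min, in the presence of a further agent that is not named here; a higher number here means that more compound is needed for the effect, a lower number that less compound is needed. Compound 1 `Cc1nn(-c2ncnc3nc[nH]c23)c2c1C(OCc1ccc(Cl)cc1Cl)CC(=O)N2` gives 4 nM. Compound 2 `Cc1nn(-c2ncnc3nc[nH]c23)c2c1C(c1ccc(OC(C)C)cc1)CC(=O)N2` gives 18 nM. Compound 3 `Cc1nn(-c2ncnc3nc[nH]c23)c2c1C(NC(=O)c1ccccc1)CC(=O)N2` gives 3 nM, the lowest of the three numbers, although the gap to compound 1 lies within the scatter: a 1.3-fold lower number from compound 1 to compound 3 (0.12 log units; within the scatter). The gap to compound 2 is clearer: a 6.0-fold lower number from compound 2 to compound 3 (0.78 log units; beyond the scatter).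

Compound 4 `Cc1nn(-c2ncnc3nc[nH]c23)c2c1C(OCCc1ccccc1)CC(=O)N2` has not been measured. It differs from compound 3 in one place: phenethyloxy in place of benzamido on a saturated ring carbon.

Within the data shown here, two measured steps bear on this change. The step of a 1.3-fold lower number from compound 1 to compound 3 (0.12 log units; within the scatter) shows that a group attached through an oxygen, the (2,4-dichlorobenzyl)oxy of compound 1, and benzamido give numbers within the scatter of each other. The step of a 6.0-fold lower number from compound 2 to compound 3 (0.78 log units; beyond the scatter), where 4-isopropoxyphenyl sits directly on the carbon, is modest but beyond the scatter. Phenethyloxy also attaches through an oxygen, yet it lacks the hydrogen-bond donor of benzamido and the chlorines of compound 1, and its chain length is not probed by any measured compound. A small rise in the number is therefore expected, with the estimate a 2.7-fold higher number from compound 3 to compound 4 (0.43 log units; beyond the scatter). Compound 4 is estimated at 8 nM, within a range from 3 nM to 25 nM.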

Compound 4, half-maximal effective concentration: 3 nM
For compound 4 the middle estimate is 2.7-fold (0.43 log units) above the measured one, within the range that was stated.
By their numbers in this assay, from the lowest: compounds 3, 4 and 1 (each within the scatter of the next); then compound 2.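

In this assay, among these compounds, no change at the digits printed from compound 3 to compound 4 (within the scatter), so at this saturated ring carbon the hydrogen-bond donor counted on benzamido, which phenethyloxy lacks, is not required for a number this low, a point the earlier compounds could not settle because compounds 1 and 3 differ in more than that donor. The comparison with the dichlorinated ether gives a 1.3-fold lower number from compound 1 to compound 4 (0.12 log units; within the scatter), so within this pair an oxygen-linked group reaches the same range with or without the two chlorines, and with benzyl in place of 2,4-dichlorophenyl on the chain carbon bound to the oxygen. Compound 2 remains apart, with a 6.0-fold lower number from compound 2 to compound 4 (0.78 log units; beyond the scatter), and it is the only compound shown with an aromatic ring placed directly on this carbon, so three quite different groups now share one range while 4-isopropoxyphenyl falls outside it.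

No measurement shown offers an explanation for why these three groups give such close numbers. The compounds shown leave open how a simple amine, a carboxylic acid or a longer chain between the oxygen and the phenyl ring would read at this position.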